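Replacing 2-fluorophenyl with 3,4,5-trimethoxyphenyl on the shared core

The source may report more compounds than this note shows. Statements on the series, on what has been measured and on what is new or still open speak of the compounds shown alone.

Measured so far in a functional assay on QGY-7703 cells (Homo sapiens) for cytotoxicity, read by MTT assay, with a stated time of 24 h; on this read-out higher numbers stand for weaker inhibition and lower numbers for stronger inhibition

Compound 1 `O=C1/C(=C/c2cccc([N+](=O)[O-])c2)CN(S(=O)(=O)c2ccc(F)cc2)C/C1=C\c1cccc([N+](=O)[O-])c1` gives 11900 nM
Compound 2 `O=C1/C(=C/c2cccc([N+](=O)[O-])c2)CN(S(=O)(=O)c2ccc(F)cc2)C/C1=C\c1ccccc1F` gives 14900 nM
Compound 3 `COc1cc(/C=C2\CN(S(=O)(=O)c3ccc(F)cc3)C/C(=C\c3ccccc3F)C2=O)cc(OC)c1` gives 14000 nM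

Compound 2 at 14900 nM stands within the scatter of both other measured compounds, so no order can be drawn among the three. The next structure is compound 4 `COc1cc(/C=C2\CN(S(=O)(=O)c3ccc(F)cc3)C/C(=C\c3cccc([N+](=O)[O-])c3)C2=O)cc(OC)c1OC` and it differs from compound 2 by a single change (3,4,5-trimethoxyphenyl in place of 2-fluorophenyl on a double-bonded chain carbon bound to a double-bonded ring carbon) with 3,4,5-trimethoxyphenyl in place of 2-fluorophenyl on a double-bonded chain carbon bound to a double-bonded ring carbon. Going by the values given here, two measured steps bear on this change, since both altered the group at that same place. One is a 1.3-fold higher number from compound 1 to compound 2 (0.10 log units; within the scatter) and the other is a 1.1-fold lower number from compound 2 to compound 3 (0.03 log units; within the scatter) and neither leaves the scatter. Among the compounds with values here, no measured compound carries 3,4,5-trimethoxyphenyl, and compound 3 with its 3,5-dimethoxyphenyl is the nearest case. In this assay no step beyond the scatter is therefore expected, the estimated step being a 1.1-fold lower number from compound 2 to compound 4 (0.06 log units; within the scatter) and no more. Compound 4 is estimated at 13000 nM with 6000 nM to 28000 nM as the expected range.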

Compound 4, half-maximal inhibitory concentration: 3270 nM
The estimate for compound 4 lay 4.0-fold (0.60 log units) above the measured number; measured number outside the range, below it.
By their numbers in this assay, from the lowest: compound 4; then compounds 1, 3 and 2 (each within the scatter of the next).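

In this assay the group on a double-bonded chain carbon bound to a double-bonded ring carbon had seemed to make little difference, but 3,4,5-trimethoxyphenyl gives a 4.6-fold lower number from compound 2 to compound 4 (0.66 log units; beyond the scatter) and a 3.6-fold lower number from compound 1 to compound 4 (0.56 log units; beyond the scatter) when it enters there. The earlier changes at this place, 2-fluorophenyl with a 1.3-fold higher number from compound 1 to compound 2 (0.10 log units; within the scatter) and 3,5-dimethoxyphenyl with a 1.1-fold lower number from compound 2 to compound 3 (0.03 log units; within the scatter), did not leave the scatter. The number at this place can therefore move, modestly, and 3,4,5-trimethoxyphenyl is the only group shown to do so.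

Nothing at hand explains why this group lowers the number. The compounds shown also leave open whether an amine or a carboxylic acid on the phenyl ring at this place would lower the number further or raise it.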